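The compounds below may be only part of what the source reports. "The series", "measured", "known", "first", "only" and "open" are said of these compounds alone.

Measured compounds:
- compound 1, `COc1ccc(S(=O)(=O)c2cnc3cc(Cl)ccc3c2N2CCC(C)CC2)cc1Cl`, 93%
- compound 2, `CC1CCN(c2c(S(=O)(=O)c3cccc(Cl)c3)cnc3cc(Cl)ccc23)CC1`, 92%
- compound 3, `COc1ccc(S(=O)(=O)c2cnc3c(F)cccc3c2N2CCC(C)CC2)cc1`, 67%

All three were tested in an assay on isolated protein for displacement of a labelled ligand from metabotropic glutamate receptor 5 (Homo sapiens), with a stated time of 60 min, tested at 1 uM; a higher number here means more inhibition at the concentration tested (going by the name of the read-out), a lower number less inhibition. Compound 1 gives 93%, compound 2 gives 92% and compound 3 gives 67%. The values of compound 1 and compound 2 lie within the scatter of each other, so nothing can be said about an order between them. Compound 3 stands apart: its number is beyond the scatter below both of the others.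

Compound 1 and compound 2 differ in one place, described as hydrogen in place of methoxy on an aromatic carbon. The step this made was a number 1 percentage points lower from compound 1 to compound 2 (within the scatter), that is, essentially no change.

Compound 4, `CC1CCN(c2c(S(=O)(=O)c3ccccc3)cnc3c(F)cccc23)CC1`, has not yet been measured. It differs from compound 3 in one place, described as hydrogen in place of methoxy on an aromatic carbon. Among the compounds with values here, this is the same kind of change as the one from compound 1 to compound 2, but not the same: in compound 1 the place is also ortho to a chloro group, whereas in compound 3 it is not. The two cores, that of compound 1 and that of compound 3, also differ; that difference is not broken down here.

Given that the earlier step was a number 1 percentage points lower from compound 1 to compound 2 (within the scatter), the expected step in this assay from compound 3 to compound 4 is a number 2 percentage points lower from compound 3 to compound 4 (within the scatter), with the caution that the surroundings of the place differ. Compound 4 is therefore expected to give about 65%, estimated between 45% and 82%.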

Compound 4, a percentage reported as inhibition, at one concentration (the size of the read-out at that concentration, not a potency): 13%
Compound 4: middle estimate off by 52 percentage points, on the high side; measured number outside the range, below it.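

In this assay, removing the methoxy group from the 4-methoxyphenyl of compound 3 gave a number 54 percentage points lower from compound 3 to compound 4 (beyond the scatter), a very different outcome from the same swap on the core of compound 1, where it gave a number 1 percentage points lower from compound 1 to compound 2 (within the scatter). So in this series, the size of this change on one core cannot simply be carried over to another, as the two steps show: the same change on two cores in this assay, a number 1 percentage points lower (within the scatter) from compound 1 to compound 2 and a number 54 percentage points lower (beyond the scatter) from compound 3 to compound 4, 53 percentage points apart, beyond the scatter of two such steps

Within the data shown here, this does not show what sets the two steps apart, since the two pairs differ from each other in more than one place, including the groups on the core and the chloro group on the aromatic ring that loses its methoxy, and only two pairs are available; each number is also a read-out at one concentration rather than a potency, so the steps do not say how far potency moved.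

The compounds shown leave open whether the fall on the core of compound 3 is specific to losing methoxy, or whether another group at the same place, such as ethoxy, hydroxy or an amine, would keep the read-out near that of compound 3. They also leave open which feature of the core of compound 1 goes with the absence of any step beyond the scatter.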